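This account rests on a few compounds, and the source may have more. Where it says the series, first, only, none or still open, it means among the compounds named here.

Of the compounds shown here, three of a shared core have been measured in a functional assay on L1210 cells (Mus musculus), with a stated time of 1 days; a lower number here means a less potent compound, a higher number a more potent compound, by a factor of ten per unit of this negative logarithm. Compound 1 `CC1=C(N2CC2)C(=O)C(Cc2ccccc2)=C(N2CC2)C1=O` gives 4.26. Compound 2 `CCOC(COC(N)=O)C1=C(N2CC2)C(=O)C(C)=C(N2CC2)C1=O` gives 4.62. Compound 3 `CC1=C(N2CC2)C(=O)C(C(C)COC(N)=O)=C(N2CC2)C1=O` gives 5.31, the highest of the three, standing a number 0.69 log units higher from compound 2 to compound 3 (beyond the scatter) and a number 1.05 log units higher from compound 1 to compound 3 (beyond the scatter).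

Compound 4 `CCC(COC(N)=O)C1=C(N2CC2)C(=O)C(C)=C(N2CC2)C1=O` has not yet been measured. It differs from compound 3 by methyl in place of hydrogen on a saturated chain carbon, two bonds along the chain from a double-bonded ring carbon, so that the side chain of compound 3 is lengthened by one carbon. Neither measured step is this change. The step from compound 2 to compound 3 is the closest in kind, since it also alters the saturated chain carbon bound to the ring, and it was modest, while the step from compound 1 to compound 3 swaps out the whole side chain and was large. Both steps raised potency toward compound 3, but neither tells how adding a single carbon on the chain will read, so no strong movement beyond the scatter is expected in either direction for compound 4 in this assay.

Compound 4 is therefore expected to give about 5.2, with a likely range from 4.7 to 5.7. This estimate means a step of a number 0.11 log units lower from compound 3 to compound 4 (within the scatter), expected to stay close to compound 3.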

Compound 4, logarithm of the reciprocal of the active concentration, log(1/C): 5.2
Estimate against measurement, compound 4: no gap at the digits printed; the measured number falls inside the stated range.
By their numbers in this assay, from the lowest: compound 1; then compound 2; then compounds 4 and 3 (each within the scatter of the next).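

In this assay, among the compounds shown here, methyl in place of hydrogen on a saturated chain carbon, two bonds along the chain from a double-bonded ring carbon, gives a number 0.11 log units lower from compound 3 to compound 4 (within the scatter) and so leaves the number within the scatter; this is the first reading of a change at this place, and the added carbon is tolerated here without a step that can be told from the scatter. Ethyl in place of ethoxy on the saturated chain carbon bound to a double-bonded ring carbon and a saturated chain carbon gives a number 0.58 log units higher from compound 2 to compound 4 (beyond the scatter) and so joins a number 0.69 log units higher from compound 2 to compound 3 (beyond the scatter) as a second modest step beyond the scatter, which means that compound 2, with its ethoxy, stands apart from both compounds that carry only carbon groups there. No measurement is at hand that would explain either step.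

On these data alone, whether the number would hold with a longer chain such as propyl at this place, or with a hydroxyl or an amine in place of the methyl, remains open. Also open, as far as these compounds go, is how a carboxylic acid at the far end of the side chain would read in this assay against compound 3 and compound 4.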